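The compounds below may be only part of what the source reports. "The series", "measured", "known", "first", "only" and "open" are said of these compounds alone.

Compound 1, `COc1cncc(-c2cccc(-c3cn4cccc(C(N)=O)c4n3)c2)c1` — in a physicochemical assay for solubility, in phosphate buffer, with a stated time of 24 h, at pH 7.4 (on this read-out higher numbers stand for higher solubility and lower numbers for lower solubility), compound 1 gives < 1000 nM, a limit of the assay rather than a number.
Compound 2, `CNC(=O)c1cccn2cc(-c3cccc(-c4cncc(OC)c4)c3)nc12` — in this assay compound 2 gives 5500 nM.

For the measured compounds named here, compound 2 thus holds the only definite number in this assay; the other value is a limit. Compound 3, `COc1cncc(-c2cccc(-c3cn4cccc(C(=O)N(C)C)c4n3)c2)c1`, differs from compound 2 by methyl in place of hydrogen on an amide-type nitrogen. One measured step is of the same kind: an at least 5.5-fold higher number from compound 1 to compound 2 (0.74 log units; beyond the scatter), which rests on (the limit of < 1000 nM in this assay, at which 1 of the 2 values shown sits). A further rise in this assay is therefore expected for compound 3, estimated as a 2.2-fold higher number from compound 2 to compound 3 (0.34 log units; beyond the scatter). Compound 3 is estimated at 12000 nM, within 4000 nM to 40000 nM.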

Compound 3, solubility: 10000 nM
For compound 3 the middle estimate is 1.2-fold (0.08 log units) above the measured one, within the range that was stated.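

In this assay, putting methyl in place of the remaining hydrogen on the amide-type nitrogen gives a 1.8-fold higher number from compound 2 to compound 3 (0.26 log units; within the scatter), so these two values cannot be told apart and the earlier rise does not visibly continue. Dimethylamino in place of amino on the carbonyl carbon gives an at least 10-fold higher number from compound 1 to compound 3 (1.00 log units; beyond the scatter). The true size of that step remains unknown, because the value for compound 1 is a limit and not a number: the limit of < 1000 nM in this assay, at which 1 of the 3 values shown sits.

As far as these compounds go, what an ethyl group, a longer chain or a morpholine ring on this nitrogen would give in this assay stays open. So does the result of a carboxylic acid in place of the amide.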